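Methylsulfonyl in place of (4-bromo-3-fluorophenyl)sulfonyl on compound 3

The compounds below may be only part of what the source reports. "The series", "measured", "known", "first", "only" and "open" are said of these compounds alone.

Three compounds share one core and differ only in the group carried on the ring nitrogen. Compound 1 `CCN(CC)c1ccc2cc(C(=O)c3ccc(N4CCN(C(=O)COc5ccc(Cl)cc5Cl)CC4)cc3)oc2c1` gives 5730 nM in a functional assay on A549 cells (Homo sapiens) for cytotoxicity, read by MTT assay, with a stated time of 48 h; a lower number here means a stronger inhibitor, a higher number a weaker inhibitor. Compound 2 `CCN(CC)c1ccc2cc(C(=O)c3ccc(N4CCN(S(=O)(=O)c5ccc(Br)cc5)CC4)cc3)oc2c1` gives 34300 nM, and compound 3 `CCN(CC)c1ccc2cc(C(=O)c3ccc(N4CCN(S(=O)(=O)c5ccc(Br)c(F)c5)CC4)cc3)oc2c1` gives 15100 nM. Compound 3 thus stands second highest of the three numbers, with a 2.3-fold lower number from compound 2 to compound 3 (0.36 log units; beyond the scatter) and a 2.6-fold higher number from compound 1 to compound 3 (0.42 log units; beyond the scatter) placing it between the other two, each gap beyond the scatter.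

Compound 4 `CCN(CC)c1ccc2cc(C(=O)c3ccc(N4CCN(S(C)(=O)=O)CC4)cc3)oc2c1` is not yet measured. It differs from compound 3 in one place: methyl in place of 4-bromo-3-fluorophenyl on a sulfonyl sulfur.

Within the data shown here, no measured step removes an aromatic ring from the sulfonyl sulfur, so nothing speaks directly to this change. What is known is that compound 1 sits lowest, with a 6.0-fold higher number from compound 1 to compound 2 (0.78 log units; beyond the scatter) and a 2.6-fold higher number from compound 1 to compound 3 (0.42 log units; beyond the scatter), and that the fluoro on the ring of compound 3 recovers part of that, seen in a 2.3-fold lower number from compound 2 to compound 3 (0.36 log units; beyond the scatter). Since compound 4 drops the whole ring carrying that fluoro, the expectation leans toward a higher number than compound 3, with wide uncertainty. Compound 4 is therefore expected at 30000 nM in this assay, between 8000 nM and 110000 nM, which means an expected step of a 2.0-fold higher number from compound 3 to compound 4 (0.30 log units; within the scatter).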

Compound 4, half-maximal inhibitory concentration: > 40000 nM
Compound 4 was reported as a limit; the forecaster's own chance of this, stated with the estimate: 20%; middle value at least 1.3-fold (0.12 log units) from the limit.
By their numbers in this assay, from the lowest: compound 1; then compound 3; then compound 2. At a limit, above all of these: compound 4.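

Compound 4 stands in this assay as a limit and not as a number: the limit of > 40000 nM in this assay, at which 1 of the 4 values shown sits. Among these compounds, this is the first look at a sulfonyl sulfur with no aromatic ring on it: methyl in place of 4-bromo-3-fluorophenyl gives an at least 2.6-fold higher number from compound 3 to compound 4 (0.42 log units; beyond the scatter), and methylsulfonyl in place of ((2,4-dichlorophenoxy)methyl)carbonyl on the ring nitrogen gives an at least 6.9-fold higher number from compound 1 to compound 4 (0.84 log units; beyond the scatter), which together show that the small methyl group does not hold the number at the level of either larger group. Methyl in place of 4-bromophenyl gives only an at least 1.1-fold higher number from compound 2 to compound 4 (0.06 log units; that floor lies within the scatter), and with that floor inside the scatter, compound 4 cannot be ranked against compound 2, so the loss is firm only against the fluorinated ring and the amide.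

As far as these compounds go, how far the true number of compound 4 lies past its limit remains open, and with it the full size of all three steps. Also open, from the compounds shown here alone, is what a plain phenyl, a 4-fluorophenyl or a longer alkyl chain such as butyl on the sulfonyl sulfur would give, and so whether the ring itself or its halogens account for the difference from methyl.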